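Methoxybenzyl series: cytotoxicity mostly at the assay limit

A few compounds are considered here, and "the series" means these few. Any claim that something is new, unique, unknown or untested is made for them only; others in the source may bear on it.

Compound 1 `COc1ccc(Cc2coc3cc(O)cc(O)c3c2=O)cc1` — > 100000 nM
Compound 2 `COc1ccccc1Cc1coc2cc(O)cc(O)c2c1=O` — 24400 nM
Compound 3 `COc1cccc(Cc2coc3cc(O)cc(O)c3c2=O)c1` — > 100000 nM

In a functional assay on H9c2 cells (Mus musculus) for cytotoxicity against H9c2 (Rattus norvegicus), read by MTT assay, with a stated time of 24 h (a higher number here means that more compound is needed for the effect, a lower number that less compound is needed), compound 1 gives > 100000 nM, which is a limit of the assay and not a number. Compound 3 likewise gives only a limit, > 100000 nM. Compound 2 gives a number, 24400 nM. Compound 1 thus stands at the limit of > 100000 nM in this assay, at which 2 of the 3 values shown sit. Going by the values given here, no two measured compounds differ in one place, so no measured step is available to guide the next one.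

Compound 4 `COc1ccc(Cc2coc3cc(O)cc(O)c3c2=O)cc1OC` differs from compound 1 by methoxy in place of hydrogen on an aromatic carbon. The step from compound 1 to compound 4 is expected to be a step that the limit leaves unreadable from compound 1 to compound 4, that is, none beyond the scatter, with a limit again the likely read-out. Compound 4 is estimated at 150000 nM, within 40000 nM to 600000 nM.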

Compound 4, half-maximal effective concentration: 12100 nM
Compound 4: middle estimate off by 12-fold (1.09 log units), on the high side; the whole stated range lies above it.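

A second methoxy, on an aromatic carbon ortho to a methoxy group, moves the series off the limit: in this assay the change gives an at least 8.2-fold lower number from compound 1 to compound 4 (0.91 log units; beyond the scatter), and read from the other monomethoxy compound it gives an at least 8.2-fold lower number from compound 3 to compound 4 (0.91 log units; beyond the scatter). Both steps give only a minimum size, because each starts from a limit: the limit of > 100000 nM in this assay, at which 2 of the 4 values shown sit.

Open, going by these compounds, is the full size of the step. Also open, on these data alone, is whether a hydroxy, an amine or a longer ether chain such as ethoxy at this place would give a similar value.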